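Replacing a pyridinyl group on piperazine with ethyl

The source may report more compounds than this note shows. Statements on the series, on what has been measured and on what is new or still open speak of the compounds shown alone.

Compound 1 `COc1ccc(CN2CCN(c3nc(Nc4ccc(C#N)c(C(F)(F)F)c4)nc(Oc4ccnc5ccccc45)n3)CC2)c(OC)c1OC` gives > 100000 nM in a functional assay on DU-145 cells (Homo sapiens) for cytotoxicity, read by sulforhodamine B assay, with a stated time of 48 h; a lower number here means a stronger inhibitor of growth, a higher number a weaker inhibitor of growth; this is a limit of the assay, not a number. Compound 2 `N#Cc1ccc(Nc2nc(Oc3ccnc4ccccc34)nc(N3CCN(c4ncccn4)CC3)n2)cc1C(F)(F)F` gives 85200 nM. Compound 3 `N#Cc1ccc(Nc2nc(Oc3ccnc4ccccc34)nc(N3CCN(c4ccccn4)CC3)n2)cc1C(F)(F)F` gives 85900 nM.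

Compound 3 stands beside compound 2 among the two numbers shown, and the step of a 1.0-fold higher number from compound 2 to compound 3 (0.00 log units; within the scatter) lies within the scatter. Going by the values given here, the only measured step thus exchanges one six-membered aromatic ring for another on the same ring nitrogen without a change that the assay can resolve.

Compound 4 `CCN1CCN(c2nc(Nc3ccc(C#N)c(C(F)(F)F)c3)nc(Oc3ccnc4ccccc34)n2)CC1` differs from compound 3 by ethyl in place of pyridin-2-yl on an amine nitrogen in a ring. No measured step exchanges an aromatic ring for a short chain at this position, so the one step shown bears on it only loosely. Given that the one step shown, a 1.0-fold higher number from compound 2 to compound 3 (0.00 log units; within the scatter), stayed within the scatter, compound 4 is expected to sit near compound 3, with an expected step of a 1.0-fold higher number from compound 3 to compound 4 (0.02 log units; within the scatter), not clearly beyond the scatter in either direction. The estimate for compound 4 is 90000 nM, with a range from 40000 nM to 200000 nM.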

Compound 4, concentration for 50% growth inhibition: 86600 nM
Compound 4: middle estimate off by 1.0-fold (0.02 log units), on the high side; the measured number falls inside the stated range.
By their numbers in this assay, from the lowest: compounds 2, 3 and 4 (each within the scatter of the next). At a limit, above all of these: compound 1.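

In this assay, the step to a short chain with no ring gives a 1.0-fold higher number from compound 3 to compound 4 (0.00 log units; within the scatter), and the matching step from the other aromatic ring gives a 1.0-fold higher number from compound 2 to compound 4 (0.01 log units; within the scatter), so at this position on the piperazine ethyl cannot be told apart from either pyridin-2-yl or pyrimidin-2-yl. Going by these compounds alone, the earlier step compared only one aromatic ring with another, whereas these steps show that removing the ring from this nitrogen altogether produces no change the assay can resolve. Compound 1 offers no firmer contrast, since the step reads an at least 1.1-fold lower number from compound 1 to compound 4 (0.06 log units; that floor lies within the scatter), and its value is a limit of the assay, not a number: the limit of > 100000 nM in this assay, at which 1 of the 4 values shown sits.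

The compounds shown leave open whether any group on this nitrogen can move the number clear of these values. A longer chain, a hydroxyethyl group, a free amine or a carboxylic acid would each test this.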